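The source may report more compounds than this note shows. Statements on the series, on what has been measured and on what is new or still open speak of the compounds shown alone.

In a functional assay on ML1 cells (Homo sapiens) for antiproliferative activity, read by WST assay, with a stated time of 3 days (a lower number here means a stronger inhibitor, a higher number a weaker inhibitor), compound 1 `O=c1cc(I)n([C@@H]2O[C@H](CO)[C@@H](O)[C@H]2O)c(=O)[nH]1` gives 15300 nM. Compound 2 `Nc1cc(=O)[nH]c(=O)n1[C@@H]1O[C@H](CO)[C@@H](O)[C@H]1O` gives > 50000 nM, which is a limit of the assay and not a number, so its position is bounded on one side only. Among the compounds with values here, the one measured step, an at least 3.2-fold higher number from compound 1 to compound 2 (0.51 log units; beyond the scatter), replaces the group on the aromatic carbon and is itself bounded by that limit. It bears only indirectly on what follows. Compound 3 `CNc1cc(=O)[nH]c(=O)n1[C@@H]1O[C@H](CO)[C@@H](O)[C@H]1O` differs from compound 2 by methyl in place of hydrogen on a nitrogen on an aromatic ring, or amino to methylamino. Within the data shown here, no measured step covers this nitrogen, so the expectation rests on the limit of compound 2 and the step already seen. In this assay the expected result is a number no higher from compound 2 to compound 3 (the limit leaves the size open), with no change beyond the scatter and a further reading at the limit as the likeliest outcome. For compound 3 the estimated value is 50000 nM, with an expected range of 20000 nM to 100000 nM.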

Compound 3, half-maximal inhibitory concentration: > 50000 nM
Compound 3 gave a limit, no number; the forecaster's own chance of this, stated with the estimate: 75%; the middle value lies on the limit itself.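

In this assay, compound 3 gives > 50000 nM, which is a limit of the assay and not a number. Replacing iodo with methylamino on this aromatic carbon gives an at least 3.2-fold higher number from compound 1 to compound 3 (0.51 log units; beyond the scatter), so the methylamino group joins the amino group on the far side of compound 1, while the step between compound 2 and compound 3 cannot be read. Adding methyl to this nitrogen therefore produces no measurable separation between the two compounds, whose readings stop at the same point: the limit of > 50000 nM in this assay, at which 2 of the 3 values shown sit.

Any effect of methyl on this nitrogen remains hidden, and it remains open whether a longer chain, as in ethylamino, or a second methyl, as in dimethylamino, would bring a reading under the limit. From the compounds shown here alone, whether the number for compound 1 is specific to iodo also remains open, and bromo or chloro on the same carbon would test this.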